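A Chloro for Methoxy Exchange

The source may report more compounds than this note shows. Statements on the series, on what has been measured and on what is new or still open speak of the compounds shown alone.

In an ADME assay on CRFK cells (Felis catus) for cytotoxicity (on this read-out lower numbers stand for higher toxicity in this test and higher numbers for lower toxicity in this test), compound 1 `CCN(CC)CN1C(=O)/C(=N/NC(=S)Nc2ccc(Cl)cc2)c2ccccc21` gives 4000 nM, compound 2 `CCN(CC)CN1C(=O)/C(=N/NC(=S)Nc2ccc(OC)cc2)c2ccccc21` gives 3500 nM and compound 3 `CCN(CC)CN1C(=O)/C(=N/NC(=S)Nc2ccc(OC)cc2)c2cc(Cl)ccc21` gives 3600 nM. Compound 3 therefore stands within the scatter of both others, and the three numbers cannot be ranked. The next case is compound 4 `CCN(CC)CN1C(=O)/C(=N/NC(=S)Nc2ccc(Cl)cc2)c2cc(Cl)ccc21`, which has chloro in place of methoxy on an aromatic carbon, para to a large group: chloro in place of methoxy on an aromatic carbon.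

For the measured compounds named here, two measured steps bear on this change. The closest is the same pair of groups exchanged in the opposite sense, methoxy in place of chloro on an aromatic carbon, which gave a 1.1-fold lower number from compound 1 to compound 2 (0.06 log units; within the scatter). The other step, chloro in place of hydrogen on an aromatic carbon, gave a 1.0-fold higher number from compound 2 to compound 3 (0.01 log units; within the scatter), and compound 4 keeps that added chloro. Neither step left the scatter, although three compounds are a narrow basis for any expectation. The expected outcome is a 1.1-fold higher number from compound 3 to compound 4 (0.03 log units; within the scatter), which would be no change beyond the scatter. Compound 4 is estimated at 3900 nM, with an expected range of 2300 nM to 6500 nM.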

Compound 4, half-maximal cytotoxic concentration: 9100 nM
For compound 4 the middle estimate is 2.3-fold (0.37 log units) below the measured one, outside the stated range (above it).
By their numbers in this assay, from the lowest: compounds 2, 3 and 1 (each within the scatter of the next); then compound 4.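

In this assay, chloro in place of methoxy on an aromatic carbon, para to a large group, now gives a step beyond the scatter on the chlorinated core, a 2.5-fold higher number from compound 3 to compound 4 (0.40 log units; beyond the scatter), a size the same pair of groups did not reach on the core of compound 1: the same change on two cores in this assay, a 1.1-fold lower number (0.06 log units; within the scatter) from compound 1 to compound 2 and a 2.5-fold lower number (0.40 log units; beyond the scatter) from compound 4 to compound 3, 2.2-fold (0.34 log units) apart, within the scatter of two such steps. The added chloro on the core likewise moves the number beyond the scatter when the 4-chlorophenyl group is present, a 2.3-fold higher number from compound 1 to compound 4 (0.36 log units; beyond the scatter), which it did not do with the 4-methoxyphenyl group: the same change on two cores in this assay, a 1.0-fold higher number (0.01 log units; within the scatter) from compound 2 to compound 3 and a 2.3-fold higher number (0.36 log units; beyond the scatter) from compound 1 to compound 4, 2.2-fold (0.34 log units) apart, within the scatter of two such steps. Each change thus passes the scatter on one core only, yet the gap between its two steps does not, so the suggestion that the two chloro groups act only in combination rests on compound 4 alone.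

On these data alone, whether this higher number, which stands for lower toxicity in this test, needs chlorine itself stays open, since a 4-fluorophenyl, 4-bromophenyl or 4-aminophenyl group could tell a specific effect of chloro from a general loss of methoxy. As far as these compounds go, it also stays open whether the result carries over when the diethylamino group gives way to a morpholine or a piperidine.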